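The source may report more compounds than this note shows. Statements on the series, on what has been measured and on what is new or still open speak of the compounds shown alone.

In a functional assay on Huh-7 cells (Homo sapiens) for cytotoxicity, read by MTT assay, with a stated time of 72 h (a lower number here means that less compound is tolerated, a higher number that more compound is tolerated), compound 1 (`O=S(=O)(CCCCl)N1CCC2(CC1)OOC1(CCCC1)OO2`) gives > 100 ug/mL as a limit of the assay, not a number. Compound 2 (`O=S(=O)(Cc1ccccc1)N1CCC2(CC1)OOC1(CCCC1)OO2`) gives > 100 ug/mL as a limit too. Compound 3 (`COc1ccc(S(=O)(=O)N2CCC3(CC2)OOC2(CCCC2)OO3)cc1`) gives > 100 ug/mL and so also stands only at a limit. The three compounds therefore rest on the limit of > 100 ug/mL in this assay, at which 3 of the 3 values shown sit, and on no measured number.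

Compound 4 (`O=S(=O)(c1ccc(F)cc1)N1CCC2(CC1)OOC1(CCCC1)OO2`) carries fluoro in place of methoxy on an aromatic carbon, para to a large group (fluoro in place of methoxy on an aromatic carbon). Among the compounds with values here, three measured steps bear on this change: a step that the two limits leave unreadable from compound 1 to compound 2 and a step that the two limits leave unreadable from compound 1 to compound 3 and a step that the two limits leave unreadable from compound 2 to compound 3 all leave the size open. They offer no size to carry over and no direction, so no step beyond the scatter is expected in this assay. The estimated step that the limit leaves unreadable from compound 3 to compound 4 is expected to be no real change. Compound 4 is expected at 120 ug/mL with an estimated range from 60 ug/mL to 250 ug/mL and may well stand only at a limit.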

Compound 4, half-maximal cytotoxic concentration: > 100 ug/mL
Compound 4: only a limit was reported; the forecaster's own chance of this, stated with the estimate: 80%; the middle value does not contradict the limit.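

In this assay compound 4 gives > 100 ug/mL, a limit of the assay and not a number. Within the data shown here, no step from compound 1, compound 2 or compound 3 to compound 4 can be read: the limit of > 100 ug/mL in this assay, at which 4 of the 4 values shown sit. The compounds shown leave open whether the groups on the sulfonyl sulfur differ at all in tolerated concentration.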